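The compounds below may be only part of what the source reports. "The series", "measured", "known", "first", "only" and "open" are said of these compounds alone.

Measured compounds:
compound 1 `Cn1c(SCC(=O)N2CCC[C@H]2C(=O)Nc2ccccc2-n2cccc2)nc2ccccc21`, in an assay on CHO cells for displacement of a labelled ligand from Orexin receptor type 2 (Homo sapiens) (a higher number here means a weaker inhibitor, a lower number a stronger inhibitor), compound 1 gives 0.3 nM;
compound 2 `COc1ccccc1-c1ccccc1NC(=O)[C@@H]1CCCN1C(=O)CCc1nc2ccccc2[nH]1`, in this assay compound 2 gives 2 nM;
compound 3 `O=C(Nc1ccccc1-c1ccccc1)[C@@H]1CCCN1C(=O)CSc1nc2ccccc2[nH]1`, in this assay compound 3 gives 0.6 nM.

Compound 1 shows the lowest number of the three. The gap to compound 3 is within the usual scatter, so the two cannot be told apart; compound 2 is the furthest from compound 1, and that gap lies beyond the scatter.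

Compound 4 `O=C(Nc1ccccc1-n1cccc1)[C@@H]1CCCN1C(=O)CSc1nc2ccccc2s1` has not been measured yet. It differs from compound 1 in one place: 1,3-benzothiazol-2-yl in place of 1-methyl-1H-benzimidazol-2-yl on a sulfur. For the measured compounds named here, nothing among the measured compounds isolates this exchange, so no measured step can be borrowed. The author therefore expects only a small change, if any, in this assay, most likely a slightly higher number, and does not expect the step from compound 1 to compound 4 to go clearly beyond the scatter: a 1.7-fold higher number from compound 1 to compound 4 (0.22 log units; within the scatter). For compound 4 the estimated value in this assay is 0.5 nM, within an expected range from 0.15 nM to 2 nM.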

Compound 4, inhibition constant: 2 nM
Compound 4: middle estimate off by 4.0-fold (0.60 log units), on the low side; the range from low to high includes it.
By their numbers in this assay, from the lowest: compounds 1 and 3 (each within the scatter of the next); then compounds 2 and 4 (each within the scatter of the next).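

For the compounds shown here, the exchange on the sulfur can be read on its own for the first time here: in this assay, 1,3-benzothiazol-2-yl in place of 1-methyl-1H-benzimidazol-2-yl gives a 6.7-fold higher number from compound 1 to compound 4 (0.82 log units; beyond the scatter), a step beyond the scatter. This position therefore responds to the choice between these two groups, even though they have the same ring types and the same counts of hydrogen-bond donors and acceptors. Nothing among the data shown accounts for the size or direction of this step.

As far as these compounds go, it remains open whether a 1,3-benzoxazol-2-yl or a 1-ethyl-1H-benzimidazol-2-yl on the same sulfur would give a number closer to that of compound 1 or to that of compound 4. Going by these compounds alone, also open is whether this exchange gives a step of similar size in other compounds, since this single pair is the only evidence for it.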